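Swapping a thioether for a benzylamine on the quinoxaline core

A few compounds are considered here, and "the series" means these few. Any claim that something is new, unique, unknown or untested is made for them only; others in the source may bear on it.

The series centres on a shared core that carries two amino groups and a phenyl group, and the compounds differ in the group that sits at the remaining position. Compound 1 `Nc1cc(N)c2nc(-c3ccccc3)c(Sc3ccc(F)cc3)nc2c1` carries a (4-fluorophenyl)sulfanyl group there, and in a functional assay on SNB-19 cells (Homo sapiens) for inhibition, read by sulforhodamine B assay, with a stated time of 48 h (a lower number here means a stronger inhibitor of growth, a higher number a weaker inhibitor of growth), compound 1 gives 20000 nM. Compound 2 `COc1cc(CNc2nc3cc(N)cc(N)c3nc2-c2ccccc2)cc(OC)c1OC` carries a benzylamino group bearing three methoxy groups, and in this assay compound 2 gives 7240 nM. Compound 3 `CCOC(=O)[C@H](CCC(=O)O)NC(=O)c1ccc(CNc2nc3cc(N)cc(N)c3nc2-c2ccccc2)cc1`, with a glutamate-derived amide on its benzylamino arm, gives in this assay only < 100000 nM, a limit of the assay rather than a number (the limit of < 100000 nM in this assay, at which 1 of the 3 values shown sits). Of the two numbers available, compound 1 stands highest, and the gap down to compound 2 lies beyond the usual scatter.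

Compound 4 `Nc1cc(N)c2nc(-c3ccccc3)c(NCc3ccc(F)cc3)nc2c1` is the untested member. Relative to compound 1 the change is (4-fluorobenzyl)amino in place of (4-fluorophenyl)sulfanyl on an aromatic carbon. Among the compounds with values here, no directly comparable pair has been measured, so the expectation for compound 4 rests on compound 2, whose benzylamino group goes with the lower value 7240 nM. A modest move toward lower numbers is therefore expected, and the step of a 2.2-fold lower number from compound 1 to compound 4 (0.35 log units; beyond the scatter) is estimated to be small, close to the edge of the scatter. Compound 4 is expected to give about 9000 nM in this assay, within a range from 3000 nM to 27000 nM.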

Compound 4, concentration for 50% growth inhibition: 6610 nM
Beside the measured number, compound 4's estimate is 1.4-fold (0.13 log units) above it; the range from low to high includes it.
By their numbers in this assay, from the lowest: compounds 4 and 2 (each within the scatter of the next); then compound 1.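

Within the data shown here, the pair of compound 1 and compound 4 is the first at this position in which the 4-fluorophenyl ring stays and only its link to the shared core changes: in this assay, (4-fluorobenzyl)amino in place of (4-fluorophenyl)sulfanyl gives a 3.0-fold lower number from compound 1 to compound 4 (0.48 log units; beyond the scatter) and so a modest step. With the benzylamino link in place, compound 4 at 6610 nM and compound 2 at 7240 nM lie within the scatter of each other, so the ring with a single fluorine and the ring with three methoxy groups cannot be told apart in this assay. Nothing measured here accounts for the step, in which the sulfur leaves and a nitrogen, a hydrogen-bond donor and one more heavy atom enter together.

As far as these compounds go, what stays open is whether the step belongs to the nitrogen or to the added carbon, a split that a (4-fluorophenyl)amino group or a (4-fluorobenzyl)sulfanyl group would show. Also open, from the compounds shown here alone, is whether an oxygen link or a nitrogen carrying a methyl group would hold the lower number that the benzylamino link gives.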